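From Cyclopentyl to Cyclohexylmethyl on the Amide Nitrogen

A few compounds are considered here, and "the series" means these few. Any claim that something is new, unique, unknown or untested is made for them only; others in the source may bear on it.

Going by the values given here, compound 3 `COc1cc(NC(C)CCCNC(=O)NC2CCCC2)c2ncccc2c1` is the only member of this small set with a numerical result. In an ADME assay on WI-38 cells (Homo sapiens), read by MTT assay, with a stated time of 72 h (a higher number here means a weaker inhibitor, a lower number a stronger inhibitor), compound 3 gives 29000 nM. Compound 1 `COc1cc(NC(C)CCCNC(=O)NC2CCCCC2)c2ncccc2c1` returns only a limit in this assay, > 100000 nM. Compound 2 `CCN(CC)C(=O)NCCCC(C)Nc1cc(OC)cc2cccnc12` likewise returns only the limit, > 100000 nM. Accordingly, the step of an at least 3.4-fold lower number from compound 1 to compound 3 (0.53 log units; beyond the scatter) shows that cyclopentyl in place of cyclohexyl on the amide-type nitrogen brought the number down from the limit into the measurable range, and an at least 3.4-fold lower number from compound 2 to compound 3 (0.53 log units; beyond the scatter) reads the same way. The step that the two limits leave unreadable from compound 1 to compound 2 cannot be sized because of the limit of > 100000 nM in this assay, at which 2 of the 3 values shown sit.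

Compound 4 `COc1cc(NC(C)CCCNC(=O)NCC2CCCCC2)c2ncccc2c1` has not been measured in this assay. Its difference from compound 3 is cyclohexylmethyl in place of cyclopentyl on an amide-type nitrogen. The step from compound 1 to compound 3 bears on it most directly: shrinking the ring gave an at least modest drop, so enlarging the group again, and further than cyclohexyl, is expected to push the number back up toward the limit. The step from compound 3 to compound 4 is therefore expected to be a 2.8-fold higher number from compound 3 to compound 4 (0.44 log units; beyond the scatter) in this assay. Compound 4 is estimated at 80000 nM, within a range from 25000 nM to 250000 nM, with a real chance that only a limit is reported.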

Compound 4, half-maximal inhibitory concentration: > 100000 nM
Compound 4 gave a limit, no number (the forecaster's own chance of this, stated with the estimate: 50%); middle value at least 1.2-fold (0.09 log units) from the limit.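

Cyclohexylmethyl in place of cyclopentyl on the amide-type nitrogen gives an at least 3.4-fold higher number from compound 3 to compound 4 (0.53 log units; beyond the scatter) in this assay, so the rise seen on going from cyclopentyl to cyclohexyl also appears with a group that carries its six-membered ring one carbon further out. Among the compounds shown, cyclopentyl is now the only group at this position with a numerical result, while cyclohexyl, cyclohexylmethyl and diethylamino all end at a limit rather than a number. The steps among compound 1, compound 2 and compound 4 cannot be read because all three compounds sit at the same limit: the limit of > 100000 nM in this assay, at which 3 of the 4 values shown sit.

From the compounds shown here alone, whether a smaller ring such as cyclobutyl or cyclopropyl would lower the number further remains open. So does the effect of a hydroxyl group or an amine on the cyclopentyl ring.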